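Sulfonamide nitrogen swaps: expectation for compound 4

The compounds below may be only part of what the source reports. "The series", "measured", "known", "first", "only" and "open" are said of these compounds alone.

Values in a functional assay on cells (leukaemia cell line, Homo sapiens) for inhibition, read by sulforhodamine B assay, with a stated time of 48 h; a higher number here means a weaker inhibitor of growth, a lower number a stronger inhibitor of growth:
- compound 1 `O=S(=O)(Nc1ccc(Cl)cc1Cl)c1ccc(-c2cnc(C3CC3)o2)cc1`: 481 nM
- compound 2 `O=S(=O)(Nc1ccc(F)c(Cl)c1)c1ccc(-c2cnc(C3CC3)o2)cc1`: 260 nM
- compound 3 `O=S(=O)(Nc1ccc(F)cc1F)c1ccc(-c2cnc(C3CC3)o2)cc1`: 356 nM

Compound 2 gives 260 nM, which lies within the scatter of the two other measured compounds. Compound 4 `O=S(=O)(Nc1cc(Cl)ccc1Cl)c1ccc(-c2cnc(C3CC3)o2)cc1`, not yet measured, differs from compound 2 in one place: 2,5-dichlorophenyl in place of 3-chloro-4-fluorophenyl on a sulfonamide nitrogen. Three measured steps involve exchanges at this same place on the sulfonamide nitrogen: a 1.9-fold lower number from compound 1 to compound 2 (0.27 log units; within the scatter), a 1.4-fold lower number from compound 1 to compound 3 (0.13 log units; within the scatter) and a 1.4-fold higher number from compound 2 to compound 3 (0.14 log units; within the scatter). All three stay within the scatter. For the measured compounds named here, compound 1 is the only measured compound with two chlorines on its phenyl group, and the step closest to the planned comparison is therefore a 1.9-fold lower number from compound 1 to compound 2 (0.27 log units; within the scatter). Going by the values given here, with only three compounds, the data do not cover the 2,5-dichlorophenyl group directly. In this assay, a small move towards a higher number is expected, but nothing beyond the scatter. The expected size is a 1.3-fold higher number from compound 2 to compound 4 (0.13 log units; within the scatter). For compound 4 the estimated value is 350 nM, with an expected range of 190 nM to 650 nM.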

Compound 4, concentration for 50% growth inhibition: 1020 nM
For compound 4 the middle estimate is 2.9-fold (0.46 log units) below the measured one; the whole stated range lies below it.
By their numbers in this assay, from the lowest: compounds 2, 3 and 1 (each within the scatter of the next); then compound 4.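

In this assay, an exchange on the sulfonamide nitrogen now goes beyond the scatter: the 2,5-dichlorophenyl group gives a 3.9-fold higher number from compound 2 to compound 4 (0.59 log units; beyond the scatter), a 2.9-fold higher number from compound 3 to compound 4 (0.46 log units; beyond the scatter) and a 2.1-fold higher number from compound 1 to compound 4 (0.33 log units; beyond the scatter). The earlier steps shown here at this place all stayed within the scatter, so the number here does respond to the phenyl group, and the last step shows that two chlorines alone do not set it: 2,4-dichlorophenyl and 2,5-dichlorophenyl differ only in how the chlorines are arranged. No available evidence bears on the reason for this shift.

Going by these compounds, all four compounds carry a phenyl group with two halogens, so the response to other kinds of group remains open. A phenyl group bearing a methoxy group or a carboxylic acid, or a simple alkyl chain in place of the phenyl group, would test how far this position tolerates change.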